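Notes on replacing phenethyl at the carbonyl carbon

A few compounds are considered here, and "the series" means these few. Any claim that something is new, unique, unknown or untested is made for them only; others in the source may bear on it.

Measured in a toxicity assay on L02 cells (Homo sapiens) for inhibition, read by MTT assay, with a stated time of 48 h; a higher number here means a weaker inhibitor, a lower number a stronger inhibitor:
- compound 1 `CCCC(=O)Nc1ccc(N2CCN(c3ccc(OC[C@@H]4CO[C@@](Cn5cncn5)(c5ccc(Cl)cc5Cl)O4)cc3)CC2)cc1`: > 50000 nM (a limit)
- compound 2 `O=C(CCc1ccccc1)Nc1ccc(N2CCN(c3ccc(OC[C@@H]4CO[C@@](Cn5cncn5)(c5ccc(Cl)cc5Cl)O4)cc3)CC2)cc1`: > 50000 nM (a limit)

Compound 2 has no number in this assay, only the limit > 50000 nM. The whole record so far is the limit of > 50000 nM in this assay, at which 2 of the 2 values shown sit.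

The next structure is compound 3 `O=C(Nc1ccc(N2CCN(c3ccc(OC[C@@H]4CO[C@@](Cn5cncn5)(c5ccc(Cl)cc5Cl)O4)cc3)CC2)cc1)C(/C=C/Cl)C/C=C/C(F)(F)F`. The change is 1-(2-chloroethenyl)-5,5,5-trifluoropent-3-en-1-yl in place of phenethyl on a carbonyl carbon. Put briefly, 1-(2-chloroethenyl)-5,5,5-trifluoropent-3-en-1-yl stands in place of phenethyl on a carbonyl carbon, so the six-membered aromatic ring of that group leaves and no ring enters.

Among the measured compounds shown here, one measured step bears on this: a step that the two limits leave unreadable from compound 1 to compound 2. It also alters the group on the carbonyl carbon, but it gives no size to carry over. No step beyond the scatter is therefore expected in this assay, in either direction, and another limit reading is the likeliest result. The expected step is a number no higher from compound 2 to compound 3 (the limit leaves the size open), which is an estimate only. For compound 3 the estimated value is 50000 nM, with an expected range of 20000 nM to 100000 nM.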

Compound 3, half-maximal inhibitory concentration: > 50000 nM
Compound 3: no number, only a limit; the forecaster's own chance of this, stated with the estimate: 75%; the middle value sits exactly at the limit.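

In this assay compound 3 gives > 50000 nM, a limit and not a number. No step among compound 1, compound 2 and compound 3 can be read, as all three readings are limits: the limit of > 50000 nM in this assay, at which 3 of the 3 values shown sit.

The compounds shown leave open whether any group on the carbonyl carbon gives a numerical value in this assay.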